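The compounds below may be only part of what the source reports. "The series", "measured", "known", "first", "only" and "open" are said of these compounds alone.

Of the compounds shown here, three sharing one core have been measured in a toxicity assay on HUVEC cells (Homo sapiens) for inhibition; on this read-out higher numbers stand for weaker inhibition of growth and lower numbers for stronger inhibition of growth. Compound 3 `Cc1nc(-c2ccccc2)c(C(=O)N2CCN(c3ccccc3)CC2)o1` gives 9.63 ug/mL, the highest number of the three and so the weakest inhibition of growth. Compound 2 `Cc1ccc(C)c(N2CCN(C(=O)c3oc(C)nc3-c3ccccc3)CC2)c1` gives 1.73 ug/mL, and compound 1 `Cc1nc(-c2ccccc2)c(C(=O)N2CCN(c3cccc(Cl)c3)CC2)o1` gives 0.463 ug/mL.

The next entry is compound 4 `Cc1nc(-c2ccccc2)c(C(=O)N2CCN(c3ccc(C)c(C)c3)CC2)o1`, which changes compound 3 as follows: 3,4-dimethylphenyl in place of phenyl on an amine nitrogen in a ring.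

The closest measured precedent is a 5.6-fold higher number from compound 2 to compound 3 (0.75 log units; beyond the scatter), a modest step beyond the scatter, with phenyl in place of 2,5-dimethylphenyl. Read in reverse, it suggests that a dimethylphenyl group gives a lower number than phenyl. The large step of a 21-fold higher number from compound 1 to compound 3 (1.32 log units; beyond the scatter), with hydrogen in place of chloro, also leaves compound 3 on top. Going by the values given here, no measured compound carries the 3,4-dimethylphenyl group, so a modest step to a lower number is expected in this assay, with wide uncertainty.

The expected size of the change is a 3.9-fold lower number from compound 3 to compound 4 (0.59 log units; beyond the scatter). For compound 4 the estimate is 2.5 ug/mL, with an expected range from 0.8 ug/mL to 8 ug/mL.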

Compound 4, concentration for 50% growth inhibition: 3.52 ug/mL
The estimate for compound 4 lay 1.4-fold (0.15 log units) below the measured number; low and high end bracket the measured number.
By their numbers in this assay, from the lowest: compound 1; then compound 2; then compound 4; then compound 3.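

In this assay the 3,4-dimethylphenyl group on the amine nitrogen in the ring also gives a lower number than phenyl (a 2.7-fold lower number from compound 3 to compound 4 (0.44 log units; beyond the scatter)), so this direction of change is no longer tied to the 2,5-dimethylphenyl group alone. The two dimethylphenyl groups do not give the same result at this position (a 2.0-fold higher number from compound 2 to compound 4 (0.31 log units; beyond the scatter)), and 3-chlorophenyl keeps the lowest number of the four compounds (a 7.6-fold higher number from compound 1 to compound 4 (0.88 log units; beyond the scatter)). Nothing available explains these differences between the groups.

The compounds shown leave open whether one methyl group on the phenyl ring would give the same lowering as two, and whether a second chloro, as in 3,4-dichlorophenyl, would go beyond 3-chlorophenyl. On these data alone, how a methoxy group or an amine on this ring would read also remains open.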